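From methyl to trifluoromethyl: the step to compound 4

A few compounds are considered here, and "the series" means these few. Any claim that something is new, unique, unknown or untested is made for them only; others in the source may bear on it.

Measured in a functional assay on SW620/5-FU cells (Homo sapiens) for cytotoxicity, read by MTT assay, with a stated time of 48 h, in the presence of a further agent that is not named here; on this read-out lower numbers stand for an effect already at smaller amounts and higher numbers for an effect only at larger amounts of compound:
- compound 1 `CCCc1cc(NNC(=O)Nc2cc(Cl)nc(Cl)c2)nc2c1c(C)nn2C` gives 40800 nM
- compound 2 `COc1ccc(-c2cc(NNC(=O)Nc3cc(Cl)nc(Cl)c3)nc3c2c(C)nn3C)cc1` gives 9700 nM
- compound 3 `Cc1nn(C)c2nc(NNC(=O)Nc3cc(Cl)nc(Cl)c3)cc(C3CCCCC3)c12` gives 22000 nM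

Compound 1 stands at the upper end of these numbers, together with compound 3, as the step between them shows: a 1.9-fold lower number from compound 1 to compound 3 (0.27 log units; within the scatter). Compound 2 lies clearly apart, with a 4.2-fold lower number from compound 1 to compound 2 (0.62 log units; beyond the scatter). The remaining pair shows a 2.3-fold higher number from compound 2 to compound 3 (0.36 log units; beyond the scatter).

Compound 4 `CCCc1cc(NNC(=O)Nc2cc(Cl)nc(Cl)c2)nc2c1c(C(F)(F)F)nn2C` has the core of compound 1 and carries trifluoromethyl in place of methyl on an aromatic carbon. This carbon belongs to the five-membered aromatic ring with 2 nitrogen. Within the data shown here, none of the measured steps touches that place, since all three exchange the group that is propyl in compound 1. They show only how far one exchange has moved the number in this assay, and they say nothing on direction at the new place. Judged by a 1.9-fold lower number from compound 1 to compound 3 (0.27 log units; within the scatter) and a 4.2-fold lower number from compound 1 to compound 2 (0.62 log units; beyond the scatter), a step within the scatter is expected, with no firm direction. The expected step is a 1.3-fold lower number from compound 1 to compound 4 (0.11 log units; within the scatter). For compound 4 the estimated value is 32000 nM, with an expected range from 14000 nM to 70000 nM.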

Compound 4, half-maximal effective concentration: 11700 nM
Compound 4: the middle estimate sits 2.7-fold (0.44 log units) above what was measured; the whole stated range lies above it.
By their numbers in this assay, from the lowest: compounds 2, 4, 3 and 1 (each within the scatter of the next, the first and the last beyond it).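

In this assay, the exchange of methyl for trifluoromethyl on an aromatic carbon of the five-membered aromatic ring with 2 nitrogen gives a 3.5-fold lower number from compound 1 to compound 4 (0.54 log units; beyond the scatter). The earlier steps shown here had exchanged only the group that is propyl in compound 1, so this result adds a second place at which a single exchange moves the number beyond the scatter, and it gives that place a first direction, towards a lower number with trifluoromethyl. The data shown offer no measurement that accounts for this shift, so its cause remains unknown.

At this place the compounds shown pair trifluoromethyl only with propyl, so it remains open whether the same exchange would lower the number in the same way on the core of compound 2 or compound 3, which carry 4-methoxyphenyl and cyclohexyl. On these data alone, it also remains open how the number would respond at this carbon to other groups, such as an ethyl group, a chlorine atom or a cyclopropyl ring, and so whether the step is particular to trifluoromethyl.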